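The source may hold more compounds than are shown below. What is called first, only, known or untested is meant among the compounds shown, and "the series" means these compounds.

Compound 2 `Cc1cccc(N2C(=O)[C@H]3[C@H](ON4[C@@H]3C(=O)N(C)[C@@]43C[C@H](C)CC[C@H]3C(C)C)C2=O)c1` is the weaker of the two measured compounds: in a functional assay, read by spectrophotometry, with a stated time of 2 h, tested at 1 mg/mL (a lower number here means a weaker effect, a higher number a stronger effect of the compound at the concentration tested), compound 2 gives 25.8%, whereas compound 1 `CC(C)[C@@H]1CC[C@@H](C)C[C@@]12N(C)C(=O)[C@@H]1[C@H]3C(=O)NC(=O)[C@H]3ON12` gives 42.6%. For the measured compounds named here, the one measured step, a number 16.8 percentage points lower from compound 1 to compound 2 (beyond the scatter), shows that adding a 3-methylphenyl on the amide-type nitrogen in the ring lowered the read-out beyond the scatter. Compound 3 `Cc1ccc(N2C(=O)[C@H]3[C@H](ON4[C@@H]3C(=O)N(C)[C@@]43C[C@H](C)CC[C@H]3C(C)C)C2=O)c(C)c1` differs from compound 2 in that same place: 2,4-dimethylphenyl in place of 3-methylphenyl on an amide-type nitrogen in a ring. Going by the values given here, no measured step exchanges one aryl group for another, so the step from compound 1 to compound 2 tells only that this nitrogen tolerates an aryl group with a loss in this assay; it does not say whether a second methyl changes anything. Compound 3 is therefore expected to stay near compound 2, with a number 1.8 percentage points lower from compound 2 to compound 3 (within the scatter) within the scatter, and its estimated read-out in this assay is 24%, in a range from 10% to 40%.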

Compound 3, a percentage reported as activity, at one concentration (the size of the read-out at that concentration, not a potency): 69%
Beside the measured number, compound 3's estimate is 45 percentage points below it; the whole stated range lies below it.
By their numbers in this assay, from the lowest: compound 2; then compound 1; then compound 3.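

Exchanging 3-methylphenyl for 2,4-dimethylphenyl on the amide-type nitrogen in a ring gives a number 43.2 percentage points higher from compound 2 to compound 3 (beyond the scatter) in this assay, so the read-out depends on which aryl group this nitrogen carries, not merely on whether it carries one. An aryl group here need not cost activity: replacing the hydrogen with 2,4-dimethylphenyl gives a number 26.4 percentage points higher from compound 1 to compound 3 (beyond the scatter), although 3-methylphenyl had lowered the read-out. No evidence at hand accounts for this difference between the two aryl groups.

On these data alone, it remains open whether 2-methylphenyl or 4-methylphenyl alone would give a similar read-out, and so which methyl group, if either alone, matters. Also open, as far as these compounds go, is how a methoxyphenyl, a carboxylic acid on the phenyl ring or a benzyl group would behave on this nitrogen.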